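The source may report more compounds than this note shows. Statements on the series, on what has been measured and on what is new or still open speak of the compounds shown alone.

Compound 1 `Nc1cc(N)c2nc(-c3ccccc3)c(Oc3ccc(Cl)c(Cl)c3)nc2c1` gives < 100000 nM in a functional assay on A549 cells (Homo sapiens) for inhibition, read by sulforhodamine B assay, with a stated time of 48 h (on this read-out higher numbers stand for lower toxicity in this test and lower numbers for higher toxicity in this test), a limit of the test rather than a number. Compound 2 `CCOC(=O)[C@H](CCC(=O)O)NC(=O)c1ccc(Sc2nc3cc(N)cc(N)c3nc2-c2ccccc2)cc1` gives < 100000 nM in this assay, also a limit. Compound 3 `COc1cc(CNc2nc3cc(N)cc(N)c3nc2-c2ccccc2)cc(OC)c1OC` gives < 50200 nM in this assay, again a limit.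

Compound 1 therefore stands at a limit, (the limit of < 100000 nM in this assay, at which 2 of the 3 values shown sit). Compound 3 sits at the limit of < 50200 nM in this assay, at which 1 of the 3 values shown sits. Since every reading is a limit, no ordering among the three compounds can be drawn.

Compound 4 `Nc1cc(N)c2nc(-c3ccccc3)c(NCc3ccc(F)cc3)nc2c1` differs from compound 1 by (4-fluorobenzyl)amino in place of 3,4-dichlorophenoxy on an aromatic carbon. Among the measured compounds shown here, no step between measured compounds is available to guide the expectation, and all three values are limits. The change is expected to move the reading by no more than the usual scatter: a step that the limit leaves unreadable from compound 1 to compound 4. Compound 4 is thus expected to give about 60000 nM in this assay, with a range from 15000 nM to 120000 nM, most likely again reported only as a limit.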

Compound 4, concentration lethal to 50% of the cells: 69200 nM
The estimate for compound 4 lay 1.2-fold (0.06 log units) below the measured number; measured number inside the range.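

No step can be read between compound 1 and compound 4: compound 1 has only a limit, while compound 4 has a number. The compounds shown leave open how (4-fluorobenzyl)amino and 3,4-dichlorophenoxy compare in this assay.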